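This account rests on a few compounds, and the source may have more. Where it says the series, first, only, none or still open, it means among the compounds named here.

Working notes on the series, all read in a functional assay on HeLa cells (Homo sapiens) for antiproliferative activity, read by MTT assay, with a stated time of 72 h; a higher number here means a weaker inhibitor, a lower number a stronger inhibitor. Compound 1 `COc1cccc(N2C(=O)COc3ccc(-c4cnc(OC)c(NS(=O)(=O)c5ccc(F)cc5)c4)cc32)c1` returns only a limit, > 40000 nM. Compound 2 `CC(C)N1C(=O)COc2ccc(-c3cnc(Cl)c(NS(=O)(=O)c4ccc(F)cc4)c3)cc21` gives 5380 nM. Compound 3 `O=C1COc2ccc(-c3cnc4ccccc4c3)cc2N1c1ccc(F)cc1` gives 38800 nM, the higher of the two numerical values in the set, and its gap to compound 2 lies beyond the scatter. Compounds 1 and 2 both differ from compound 3 in more than one place, so neither gives a direct read on a single substituent.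

The next entry is compound 4 `O=C1COc2ccc(-c3cnc4ccccc4c3)cc2N1c1ccccc1`, which keeps the shared core of compound 3 and changes one position: hydrogen in place of fluoro on an aromatic carbon, para to a large group, so that 4-fluorophenyl becomes phenyl (hydrogen in place of fluoro on an aromatic carbon). For the measured compounds named here, no measured pair isolates this change, so the expectation rests on compound 3 at 38800 nM and on the small size of the edit. In this assay, no step beyond the scatter is expected, in either direction. The expected move is a 1.3-fold lower number from compound 3 to compound 4 (0.11 log units; within the scatter). Compound 4 could also return only a limit rather than a number. For compound 4 the estimated value is 30000 nM, with an expected range from 13000 nM to 40000 nM.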

Compound 4, half-maximal inhibitory concentration: > 40000 nM
Compound 4: only a limit was reported; the forecaster's own chance of this, stated with the estimate: 30%; middle value at least 1.3-fold (0.12 log units) from the limit.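

For the compounds shown here, compound 4 gives the first comparison that differs in one place, with 4-fluorophenyl on the shared core of compound 3 becoming phenyl. In this assay compound 4 returns only a limit, > 40000 nM. The step reads an at least 1.0-fold higher number from compound 3 to compound 4 (0.01 log units; that floor lies within the scatter), so it sets only a floor, and that floor shows no move beyond the scatter on losing the fluoro; the true size of the step stays unresolved because compound 4 sits at a limit: the limit of > 40000 nM in this assay, at which 2 of the 4 values shown sit.

Whether an amine or a carboxylic acid on this aromatic carbon, para to a large group, would shift the number beyond the scatter remains open, since hydrogen and fluoro are the only two groups shown at this place. Compound 2, at 5380 nM, differs from compound 3 in more than one place. The compounds shown therefore also leave open whether this edit would read differently on a compound whose values both fall clear of the limit.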